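The source may report more compounds than this note shows. Statements on the series, on what has been measured and on what is new or still open speak of the compounds shown alone.

Measured so far:
- compound 1 `CCOC(=O)c1c(N)sc(-c2ccccc2Cl)c1C`: 5700 nM
- compound 2 `CCOC(=O)c1c(N)sc(-c2ccccc2)c1-c1ccccc1`: 4500 nM
- compound 3 `COC(=O)c1c(N)sc(-c2ccccc2)c1C`: 4100 nM

Of the compounds shown here, three on a shared core have been tested in an in vitro functional assay on HEK293 cells for antagonist activity at metabotropic glutamate receptor 6 (Homo sapiens), read by reporter gene assay, luminescence and calcium flux, tested at 10 uM; on this read-out lower numbers stand for stronger inhibition and higher numbers for weaker inhibition. Compound 1 gives 5700 nM, compound 2 gives 4500 nM, and compound 3 gives 4100 nM. Compound 3 stands at the lowest of the three numbers, but its gap to compound 2 and its gap to compound 1 both lie within the scatter of this assay, so the three compounds read as one level rather than as a ranked series.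

Compound 4 `Cc1c(-c2ccccc2)sc(N)c1C(=O)c1ccccc1` has not yet been measured. It differs from compound 3 in one place: phenyl in place of methoxy on a carbonyl carbon. For the measured compounds named here, none of the measured pairs differs in this way, so there is no measured step to lean on. The changes that are covered among compounds 1, 2 and 3 all leave the numbers within the scatter, and nothing in the data points to a direction for this new change. The step from compound 3 to compound 4 is therefore expected to be a 1.1-fold higher number from compound 3 to compound 4 (0.04 log units; within the scatter), that is, none beyond the scatter. Compound 4 is estimated to give 4500 nM in this assay, within a range of 1500 nM to 14000 nM.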

Compound 4, half-maximal inhibitory concentration: 10600 nM
Compound 4: the middle estimate sits 2.4-fold (0.37 log units) below what was measured; the measured number falls inside the stated range.
By their numbers in this assay, from the lowest: compounds 3, 2, 1 and 4 (each within the scatter of the next, the first and the last beyond it).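

In this assay, the carbonyl carbon proves to be a place where the number can move: phenyl in place of methoxy gives a 2.6-fold higher number from compound 3 to compound 4 (0.41 log units; beyond the scatter), a modest step toward weaker inhibition and the only listed step between compounds that differ in one place. Compounds 1, 2 and 3 had read as one level, so they gave no sign that any change on the shared core could carry the number beyond the scatter. This single step swaps a small group that counts a hydrogen-bond acceptor for a larger one with a six-membered aromatic ring and no such acceptor, and no supporting data are available to say which of these differences matters or why the number rises.

What the compounds shown leave open is how other groups on this carbonyl carbon would read, such as a dimethylamino group, a hydroxyl or a cyclohexyl, any of which would help to separate the presence of a ring from the loss of the oxygen. They also leave open whether the same change would give a similar step on the other substitution patterns of the core.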